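The compounds below may be only part of what the source reports. "The series", "measured", "known", "first", "only" and "open" are said of these compounds alone.

Working notes on the series. In a functional assay on HepG2 cells (Homo sapiens) for antiproliferative activity, read by MTT assay (a higher number here means a weaker inhibitor, a lower number a stronger inhibitor), compound 1 (`COc1ccc(-c2ccnc(Nc3ccc([N+](=O)[O-])cc3)n2)cc1`) gives 1040 nM and compound 2 (`O=[N+]([O-])c1ccc(Nc2nccc(-c3ccc(Br)cc3)n2)cc1`) gives 43000 nM, so compound 2 holds the higher of the two numbers. Compound 3 (`O=[N+]([O-])c1ccc(Nc2nccc(-c3ccc(F)cc3)n2)cc1`) has fluoro in place of bromo on an aromatic carbon, para to a large group, which reads 4-bromophenyl to 4-fluorophenyl. Among the measured compounds shown here, the only measured step at this place is bromo in place of methoxy (a 41-fold higher number from compound 1 to compound 2 (1.62 log units; beyond the scatter)), which is large and beyond the scatter. For the measured compounds named here, it shows that a swap here can move the number widely, but no fluoro compound has been measured and one step gives no trend. With compound 2 at 43000 nM as the high end so far, a moderate step to a lower number is expected in this assay for this swap. The estimated step is a 4.8-fold lower number from compound 2 to compound 3 (0.68 log units; beyond the scatter) and carries wide uncertainty. Compound 3 is expected at 9000 nM with an estimated range of 2000 nM to 40000 nM in this read-out.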

Compound 3, half-maximal inhibitory concentration: 7950 nM
The estimate for compound 3 lay 1.1-fold (0.05 log units) above the measured number; the range from low to high includes it.
By their numbers in this assay, from the lowest: compound 1; then compound 3; then compound 2.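

In this assay the halogen itself matters at this position: 4-bromophenyl to 4-fluorophenyl is a change of one heavy atom for one heavy atom, yet it gives a step beyond the scatter (a 5.4-fold lower number from compound 2 to compound 3 (0.73 log units; beyond the scatter)). Fluoro does not recover the whole loss seen with bromo, since methoxy still holds the lowest number of the three (a 7.6-fold higher number from compound 1 to compound 3 (0.88 log units; beyond the scatter)), and all three groups are separated by steps beyond the scatter, with fluoro in the middle. No measured evidence on the compounds accounts for this order.

On these data alone, whether the order holds for other groups at this place, such as chloro, an amine or a carboxylic acid, stays open. The compounds shown also leave open whether these swaps give similar steps when the rest of the structure changes.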